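Thiophene-fused series: aryl versus methyl and microsomal half-life

This account rests on a few compounds, and the source may have more. Where it says the series, first, only, none or still open, it means among the compounds named here.

Compound 2 `CCCNC(=O)C1CCN(C(=O)c2cc3sc(C)cc3n2Cc2ccc(OC)cc2)CC1` is the shorter-lived of the two compounds measured in an ADME assay on microsomes from liver (Homo sapiens) for metabolic stability; a lower number here means that the compound disappears faster, a higher number that the compound lasts longer: compound 2 gives 0.0448 h, the lowest of the two numbers. Where compound 2 carries a methyl, compound 1 `CCCNC(=O)C1CCN(C(=O)c2cc3sc(-c4ccccc4)cc3n2Cc2ccc(OC)cc2)CC1` carries a phenyl, and compound 1 gives 0.737 h in this assay. Going by the values given here, the only step measured so far is a 16-fold lower number from compound 1 to compound 2 (1.22 log units; beyond the scatter), well beyond the scatter.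

Compound 3 `CCCNC(=O)C1CCN(C(=O)c2cc3sc(-c4ccccc4F)cc3n2Cc2ccc(OC)cc2)CC1` differs from compound 2 by 2-fluorophenyl in place of methyl on an aromatic carbon. This change runs in the opposite direction to the measured step: an aromatic ring returns to the same carbon, now as 2-fluorophenyl rather than phenyl. Because a 16-fold lower number from compound 1 to compound 2 (1.22 log units; beyond the scatter) was large, a step of similar size in the opposite direction is expected in this assay, bringing compound 3 back toward compound 1; the fluorine is an untested variable, so the width of the range is kept generous. For compound 3 the expected step is a 13-fold higher number from compound 2 to compound 3 (1.13 log units; beyond the scatter). Compound 3 is therefore estimated at 0.6 h, within a range from 0.2 h to 1.8 h.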

Compound 3, half-life: 0.592 h
Estimate against measurement, compound 3: 1.0-fold (0.01 log units) above, and the stated range covers the measured number.
By their numbers in this assay, from the lowest: compound 2; then compounds 3 and 1 (each within the scatter of the next).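

Working notes: at the aromatic carbon next to the ring sulfur, the large difference in this assay is not unique to the unsubstituted phenyl, as 2-fluorophenyl in place of methyl gives a 13-fold higher number from compound 2 to compound 3 (1.12 log units; beyond the scatter) and this now stands as a second aryl group against the single methyl. On the aryl group itself, fluoro in place of hydrogen gives a 1.2-fold lower number from compound 1 to compound 3 (0.10 log units; within the scatter) and so leaves no difference beyond the scatter, which means that this one fluorine on the phenyl does not separate compound 1 from compound 3 in this read-out. The two aryl compounds therefore agree at this carbon, and compound 2 alone stands apart from them, but nothing available bears on why the half-life tracks the group at this carbon in this way.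

Still open, from the compounds shown here alone, is whether an aromatic ring is needed at this carbon or whether a saturated ring such as cyclohexyl, or a longer chain such as butyl, would go with numbers like those of compound 1 and compound 3. Also open, going by these compounds, is how a ring nitrogen, as in pyridyl, or a larger substituent on the phenyl, such as methoxy or trifluoromethyl, would read in this assay at this same carbon.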